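Swapping an ether linker for a direct chlorinated biaryl

The source may report more compounds than this note shows. Statements on the series, on what has been measured and on what is new or still open speak of the compounds shown alone.

Compound 3 `CN1Cc2ccc(OCc3ccc(Oc4ccc(F)cc4)cc3)cc2[C@@H](O)C1` is the reference point here. In an ADME assay on Vero cells (Chlorocebus sabaeus) for cytotoxicity, read by sulforhodamine B assay, with a stated time of 72 h (a lower number here means a stronger inhibitor, a higher number a weaker inhibitor), compound 3 gives 5600 nM, which is the lowest of the two numbers recorded. Its nearest neighbour is compound 2 `CN1Cc2ccc(OCc3ccc(-c4ccccc4)cc3)cc2[C@@H](O)C1`, which gives 23000 nM in this assay, so a 4.1-fold lower number from compound 2 to compound 3 (0.61 log units; beyond the scatter). Compound 1 `CN1Cc2ccc(OCc3ccccc3)cc2[C@@H](O)C1` is different in kind: in this assay compound 1 gives only a limit, > 100000 nM, and the limit of > 100000 nM in this assay, at which 1 of the 3 values shown sits, is the boundary it sits at. Against that boundary, an at least 4.3-fold lower number from compound 1 to compound 2 (0.63 log units; beyond the scatter) and an at least 17-fold lower number from compound 1 to compound 3 (1.25 log units; beyond the scatter).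

Compound 4 `CN1Cc2ccc(OCc3ccc(-c4cccc(Cl)c4)cc3)cc2[C@@H](O)C1` is not yet measured. Relative to compound 3 the change is 3-chlorophenyl in place of 4-fluorophenoxy on an aromatic carbon. Among the compounds with values here, the step that bears most directly on this is the one from compound 2 to compound 3, where going from phenyl to 4-fluorophenoxy gave a modest drop; compound 4 returns to a directly attached phenyl ring, now carrying a chlorine, so part of that step is expected to be undone. A modest rise in the number relative to compound 3 is therefore expected, landing between compound 2 and compound 3. For compound 4 the expected result in this assay is 12000 nM, with a range of 5000 nM to 30000 nM, meaning an expected step of a 2.1-fold higher number from compound 3 to compound 4 (0.33 log units; beyond the scatter).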

Compound 4, half-maximal inhibitory concentration: 25500 nM
Compound 4: middle estimate off by 2.1-fold (0.33 log units), on the low side, and the stated range covers the measured number.
By their numbers in this assay, from the lowest: compound 3; then compounds 2 and 4 (each within the scatter of the next). At a limit, above all of these: compound 1.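

In this assay, the chlorine on the directly attached ring makes no difference that can be told apart from scatter: a 1.1-fold higher number from compound 2 to compound 4 (0.04 log units; within the scatter), so compound 2 and compound 4 read as equal. Replacing the 4-fluorophenoxy group with 3-chlorophenyl gives a 4.6-fold higher number from compound 3 to compound 4 (0.66 log units; beyond the scatter), which shows that a halogen on the end ring is not enough to keep the low number of compound 3, and that among these compounds that number goes with the 4-fluorophenoxy group as a whole. The 3-chlorophenyl group still gives an at least 3.9-fold lower number from compound 1 to compound 4 (0.59 log units; beyond the scatter), a step that rests on a limit rather than a measured number: the limit of > 100000 nM in this assay, at which 1 of the 4 values shown sits.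

The compounds shown do not separate the ether oxygen from the fluorine, since compound 3 and compound 4 differ in both the linking atom and the halogen; a plain phenoxy group or a 4-fluorophenyl group would pull the two apart. Also open, as far as these compounds go, is whether a different kind of group on that end ring, such as a nitrile or a carboxylic acid, would move the number at all.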